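The source may report more compounds than this note shows. Statements on the series, on what has been measured and on what is new or still open speak of the compounds shown alone.

Measured compounds and their values:

Compound 1, `CCOC(=O)Nc1ccc(S(=O)(=O)N2C[C@H](c3ccccc3)NC2=O)cc1C`, gives 70 nM in a functional assay on HCT-116 cells (Homo sapiens) for cytotoxicity, read by MTT assay; a higher number here means a weaker inhibitor, a lower number a stronger inhibitor.
Compound 2, `Cc1cc(S(=O)(=O)N2C(=O)N[C@@H](c3ccccc3)C2C)ccc1NC(=O)c1ccc(N)cc1`, reaches only a limit of the assay, > 10000 nM.
Compound 3, `Cc1cc(S(=O)(=O)N2C(=O)N[C@@H](c3ccccc3)C2C)ccc1NC(=O)c1ccc([N+](=O)[O-])cc1`, likewise reaches only a limit of the assay, > 10000 nM.

Compound 3 therefore stands at the top edge of what this assay can report: no true number is known for it, only that its potency lies beyond the assay's reach, a situation shared with compound 2 and summed up by the limit of > 10000 nM in this assay, at which 2 of the 3 values shown sit. Among the measured compounds shown here, the one measured step that touches compound 3, a step that the two limits leave unreadable from compound 2 to compound 3, runs from one limit to another and so gives no readable size.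

Compound 4, `CC1[C@H](c2ccccc2)NC(=O)N1S(=O)(=O)c1ccc(NC(=O)c2ccc([N+](=O)[O-])cc2)c(Cl)c1`, differs from compound 3 by chloro in place of methyl on an aromatic carbon. No measured pair among the compounds shown exchanges methyl for chloro, so no step is available to set an expected size or direction in this assay for this change. With compound 3 already at a limit and no guidance from a comparable step, the most reasonable expectation is that compound 4 stays in the same region, so the expected step of a number no higher from compound 3 to compound 4 (the limit leaves the size open) is essentially none beyond the scatter. Compound 4 is accordingly estimated at 10000 nM, with a likely range from 3000 nM to 30000 nM.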

Compound 4, half-maximal inhibitory concentration: > 10000 nM
Compound 4 ended at the assay's limit; the forecaster's own chance of this, stated with the estimate: 80%; the middle value sits exactly at the limit.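

Compound 3 and compound 4 both rest at a limit of this assay rather than at a true number, so the exchange of methyl for chloro gives no step that can be read: the limit of > 10000 nM in this assay, at which 3 of the 4 values shown sit.

The compounds shown leave open how strongly compound 3 and compound 4 act in this assay, and whether chloro in place of methyl changes that at all.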